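Aryl-substituted tetrazolyl amides: alkyl chain growth and oral inhibition

The source may hold more compounds than are shown below. What is called first, only, known or untested is meant among the compounds shown, and "the series" means these compounds.

Compound 1 `CCc1ccc(-c2cc(Cl)cc(C(=O)Nc3nn[nH]n3)n2)cc1` is measured in a functional assay on the whole organism with Rattus norvegicus as the target, at a dose of 3 mg/kg by the oral route (on this read-out lower numbers stand for a weaker effect and higher numbers for a stronger effect at the one dose given), where compound 1 gives 100%. Compound 2 `CC(C)c1ccc(-c2cc(Cl)cc(C(=O)Nc3nn[nH]n3)n2)cc1` differs from compound 1 by methyl in place of hydrogen on a saturated chain carbon bound to an aromatic carbon and a saturated chain carbon; in this assay compound 2 gives 68%, so a number 32 percentage points lower from compound 1 to compound 2 (beyond the scatter). Compound 3 `Cc1cc(C(=O)Nc2nn[nH]n2)nc(-c2ccccc2)c1` has a different core, and the difference between the two cores is not broken down here; in this assay compound 3 gives 50%, which places it lowest of the three, with compound 2 nearest and compound 1 furthest.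

Compound 4 `CCc1cc(C(=O)Nc2nn[nH]n2)nc(-c2ccccc2)c1` has not yet been measured in this assay. It differs from compound 3 by methyl in place of hydrogen on a saturated chain carbon bound to an aromatic carbon. This is the same kind of change as that from compound 1 to compound 2, not the same: there the place was on a saturated chain carbon bound to an aromatic carbon and a saturated chain carbon, here it is on a saturated chain carbon bound to an aromatic carbon only, and the group sits on the core of compound 3 rather than where the earlier change was made. Among the measured compounds shown here, with only one prior example of this kind of change, on a different core and at a different place, the earlier drop carries limited weight. The step from compound 3 to compound 4 is expected to be small, no change at the digits printed from compound 3 to compound 4 (within the scatter), within the usual scatter, with a wide margin either way. Compound 4 is therefore estimated at 50%, between 20% and 80%, in this assay.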

Compound 4, a percentage reported as inhibition, in the whole organism at one dose (the size of the read-out at that dose, not a potency): 53%
Beside the measured number, compound 4's estimate is 3 percentage points below it, and the stated range covers the measured number.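

In this assay, methyl in place of hydrogen on a saturated chain carbon bound to an aromatic carbon gives a number 3 percentage points higher from compound 3 to compound 4 (within the scatter), so the large drop seen with the earlier change does not reappear on the core of compound 3: the same change on two cores in this assay, a number 32 percentage points lower (beyond the scatter) from compound 1 to compound 2 and a number 3 percentage points higher (within the scatter) from compound 3 to compound 4, 35 percentage points apart, beyond the scatter of two such steps Within this series, the effect of adding this methyl therefore cannot be carried from one core to another as a fixed increment, and the result for the pair compound 1 and compound 2 gives no safe forecast for a related pair on another core. This does not show that the core alone sets the outcome, since the two pairs differ both in core and in the carbon that receives the methyl, and two pairs at one oral dose can support no general rule or any statement about potency.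

The compounds shown leave open whether a longer chain such as propyl or butyl in place of the ethyl of compound 4 would keep the read-out level with that of compound 4 or move it beyond the scatter. They also leave open how a hydroxyl or an amine on that chain would behave, and whether either result would hold on the core of compound 1.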